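Adding One Methyl to Compound 2

A few compounds are considered here, and "the series" means these few. Any claim that something is new, unique, unknown or untested is made for them only; others in the source may bear on it.

Measured so far in a functional assay on HT-29 cells (Homo sapiens) for inhibition, read by sulforhodamine B assay, with a stated time of 48 h (on this read-out higher numbers stand for weaker inhibition of growth and lower numbers for stronger inhibition of growth), are two compounds:
- compound 1 (`O=C(CCl)NC(=O)Nc1ccc(-c2ccccc2)cc1`) with 2300 nM
- compound 2 (`Cc1ccc(NC(=O)NC(=O)CCl)cc1`) with 10000 nM

Among the measured compounds shown here, compound 2 holds the higher of the two numbers, so it is the weaker growth inhibitor of the pair, and compound 1 is its only neighbour. The next compound, compound 3 (`Cc1ccc(NC(=O)NC(=O)CCl)cc1C`), carries methyl in place of hydrogen on an aromatic carbon and has yet to be measured.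

For the measured compounds named here, only one measured step bears on this change. It is a 4.3-fold higher number from compound 1 to compound 2 (0.64 log units; beyond the scatter) and it comes from methyl in place of phenyl on an aromatic carbon. That swap is a much larger structural change than one added methyl, so a much smaller step is expected in this assay here. Going by the values given here, a single pair shows no trend, and no measured step adds a methyl to the ring of compound 2. The estimated step is a 1.4-fold lower number from compound 2 to compound 3 (0.15 log units; within the scatter) and it is expected to stay within the scatter, if anything towards a lower number. For compound 3 the expected value is 7000 nM as the middle estimate, with an estimated range (2800 nM to 17000 nM).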

Compound 3, concentration for 50% growth inhibition: 6900 nM
Compound 3: middle estimate off by 1.0-fold (0.01 log units), on the high side, and the stated range covers the measured number.
By their numbers in this assay, from the lowest: compound 1; then compounds 3 and 2 (each within the scatter of the next).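

In this assay, a methyl placed ortho to a methyl group and meta to a group of 8 heavy atoms gives a 1.4-fold lower number from compound 2 to compound 3 (0.16 log units; within the scatter) and so stays within the scatter, which means this position of the ring accepts one added methyl with no change that can be read in this assay. Among the compounds shown here, the earlier step, a 4.3-fold higher number from compound 1 to compound 2 (0.64 log units; beyond the scatter) and beyond the scatter, came from methyl in place of phenyl and said nothing about adding a group while the existing methyl stays, so this is the first measured case of that change. No measurement of any other kind accompanies the result, and nothing shown accounts for the size of this step.

The compounds shown leave open whether a larger or different group at this same place, such as an ethyl, a methoxy group, a chlorine or an amine, would also stay within the scatter of compound 2 or would move the number beyond it. They also leave open whether a methyl added in the same way to the core of compound 1 would give a similarly small step.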